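Replacing the pyridylmethyl arm of compound 1 with a thiane ring

A few compounds are considered here, and "the series" means these few. Any claim that something is new, unique, unknown or untested is made for them only; others in the source may bear on it.

Compound 1 `c1cncc(CNCCCCN(C[C@H]2Cc3ccccc3CN2)[C@H]2CCCc3cccnc32)c1` is the reference of this small set. In a functional assay on cells for antagonist activity at C-X-C chemokine receptor type 4 (Homo sapiens), read by fluorescence and calcium flux, with stated times of 25 min and 90 s (a lower number here means a stronger inhibitor, a higher number a weaker inhibitor), compound 1 gives 15.3 nM, the lowest number of the three. Compound 2 `c1ccc2c(c1)CN[C@@H](CN(CCCCNCc1ccncc1)[C@H]1CCCc3cccnc31)C2` gives 22.7 nM and compound 3 `c1ccc2c(c1)CN[C@@H](CN(CCCCNCC1CCNCC1)[C@H]1CCCc3cccnc31)C2` gives 36.5 nM. The step of a 1.5-fold higher number from compound 1 to compound 2 (0.17 log units; within the scatter) lies within the scatter; the step of a 2.4-fold higher number from compound 1 to compound 3 (0.38 log units; beyond the scatter) is modest but beyond it, and a 1.6-fold higher number from compound 2 to compound 3 (0.21 log units; within the scatter) stays within the scatter.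

Compound 4 `c1ccc2c(c1)CN[C@@H](CN(CCCCNC1CCSCC1)[C@H]1CCCc3cccnc31)C2` differs from compound 1 by thian-4-yl in place of (pyridin-3-yl)methyl on an amine nitrogen. Among the measured compounds shown here, the nearest precedent is compound 3, where a six-membered non-aromatic ring also enters in place of pyridin-3-yl and the number rises by a 2.4-fold higher number from compound 1 to compound 3 (0.38 log units; beyond the scatter). A step of similar size, toward a higher number, is expected here, so for compound 4 the estimate is 50 nM (range 20 nM to 130 nM), an expected step of a 3.3-fold higher number from compound 1 to compound 4 (0.51 log units; beyond the scatter).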

Compound 4, half-maximal inhibitory concentration: 54.7 nM
Compound 4: the middle estimate sits 1.1-fold (0.04 log units) below what was measured, and the stated range covers the measured number.
By their numbers in this assay, from the lowest: compounds 1, 2, 3 and 4 (each within the scatter of the next, the first and the last beyond it).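

On the amine nitrogen, thian-4-yl still gives a number of the same order as the other arms: a 3.6-fold higher number from compound 1 to compound 4 (0.55 log units; beyond the scatter) and a 2.4-fold higher number from compound 2 to compound 4 (0.38 log units; beyond the scatter) are both modest, while a 1.5-fold higher number from compound 3 to compound 4 (0.18 log units; within the scatter) stays within the scatter. The arm of compound 4 therefore holds neither an aromatic ring nor a ring nitrogen, and compound 3 cannot be told apart from it. No measured evidence bears on why these steps take this size.

The sulfur ring atom and the loss of the methylene link change together in compound 4. A (thian-4-yl)methyl arm on the same amine nitrogen would separate the two, and an oxygen ring atom in place of sulfur would test the hetero atom.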